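The source may report more compounds than this note shows. Statements on the series, on what has been measured and on what is new or still open speak of the compounds shown alone.

Compound 1, `COC(=O)C(=O)CNC1=CS(=O)(=O)O[C@@]12[C@@H](CO[Si](C)(C)C(C)(C)C)O[C@@H](n1cc(C)c(=O)n(C)c1=O)[C@@H]2O[Si](C)(C)C(C)(C)C`: in a functional assay on HEL cells (Homo sapiens) (on this read-out higher numbers stand for lower toxicity in this test and lower numbers for higher toxicity in this test), compound 1 gives a value that is a limit of the assay, > 200000 nM.
Compound 2, `Cc1cn([C@@H]2O[C@H](CO[Si](C)(C)C(C)(C)C)[C@@]3(OS(=O)(=O)C=C3NC(N)=O)[C@H]2O[Si](C)(C)C(C)(C)C)c(=O)n(C)c1=O`: compound 2 gives 11000 nM.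
Compound 3, `COC(=O)CC(=O)NC1=CS(=O)(=O)O[C@@]12[C@@H](CO[Si](C)(C)C(C)(C)C)O[C@@H](n1cc(C)c(=O)n(C)c1=O)[C@@H]2O[Si](C)(C)C(C)(C)C`: compound 3 gives 29000 nM.

Of the two numbers, that of compound 3 is the higher. The nearest number is separated by a 2.6-fold higher number from compound 2 to compound 3 (0.42 log units; beyond the scatter). Compound 4, `Cc1cn([C@@H]2O[C@H](CO[Si](C)(C)C(C)(C)C)[C@@]3(OS(=O)(=O)C=C3NCC(=O)C(=O)N3CCC3)[C@H]2O[Si](C)(C)C(C)(C)C)c(=O)n(C)c1=O`, is not yet measured; it differs from compound 3 in one place: (((azetidin-1-yl)carbonyl)carbonyl)methyl in place of ((methoxycarbonyl)methyl)carbonyl on an amine nitrogen. The step that bears on it is the reverse of an at least 6.8-fold lower number from compound 1 to compound 3 (0.83 log units; beyond the scatter), where the ((methoxycarbonyl)carbonyl)methyl arrangement sits at the limit (the limit of > 200000 nM in this assay, at which 1 of the 3 values shown sits). Compound 4 brings a carbonyl-carbonyl-methyl arrangement back, with an azetidine amide where the methyl ester was, so the step of a 3.4-fold higher number from compound 3 to compound 4 (0.54 log units; beyond the scatter) is expected to raise the number beyond the scatter. Compound 4 is therefore estimated at 100000 nM, within 30000 nM to 300000 nM.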

Compound 4, half-maximal cytotoxic concentration: 84400 nM
The estimate for compound 4 lay 1.2-fold (0.07 log units) above the measured number, and the stated range covers the measured number.
By their numbers in this assay, from the lowest: compound 2; then compound 3; then compound 4. At a limit, above all of these: compound 1.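

In this assay, the carbonyl-carbonyl-methyl arrangement on this amine nitrogen now has a number that is not a limit, and that number lies beyond the two acylated amines: a 2.9-fold higher number from compound 3 to compound 4 (0.46 log units; beyond the scatter) and a 7.7-fold higher number from compound 2 to compound 4 (0.88 log units; beyond the scatter). Azetidin-1-yl in place of methoxy on the carbonyl carbon gives an at least 2.3-fold lower number from compound 1 to compound 4 (0.37 log units; beyond the scatter), a step with only one bound. Compound 1 remains a limit of the assay: the limit of > 200000 nM in this assay, at which 1 of the 4 values shown sits.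

As far as these compounds go, whether a pyrrolidine amide, a dimethylamine amide or a carboxylic acid at that carbonyl carbon would move the number in the same direction remains open. From the compounds shown here alone, the true size of the azetidine-for-methoxy step also remains open.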